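Cyclopropyl for propyl on the amine of compound 2

A few compounds are considered here, and "the series" means these few. Any claim that something is new, unique, unknown or untested is made for them only; others in the source may bear on it.

Of the compounds shown here, two from this series have been tested in an ADME assay on MT4 cells (Homo sapiens) for cytotoxicity, read by MTT assay, with a stated time of 5 days; on this read-out higher numbers stand for lower toxicity in this test and lower numbers for higher toxicity in this test. Compound 1 `N#C/C=C/c1ccc(C(NC2CC2)c2ccnc(Nc3ccc(C#N)cc3)n2)cc1` gives 56100 nM in this assay, and compound 2 `CCCNC(c1ccc(C#N)cc1)c1ccnc(Nc2ccc(C#N)cc2)n1` gives 34900 nM. On paper compound 2 carries the smaller of the two numbers, but the gap to compound 1 lies within the usual scatter of this assay, so the two compounds cannot be told apart on this read-out.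

Compound 3 `N#Cc1ccc(Nc2nccc(C(NC3CC3)c3ccc(C#N)cc3)n2)cc1` has not yet been measured. It differs from compound 2 in a single place: cyclopropyl in place of propyl on an amine nitrogen. Going by the values given here, no pair of measured compounds differing only in this way is available, so the size of the step cannot be read from the data. Compound 1, which also carries the cyclopropylamino group, gives a number that sits within the scatter of compound 2, which suggests that the exchange of the chain for the small ring leaves the read-out roughly where it is.

The step from compound 2 to compound 3 is therefore expected to be small, a 1.1-fold higher number from compound 2 to compound 3 (0.06 log units; within the scatter), in either direction, and not beyond the scatter. Compound 3 is estimated at 40000 nM in this assay, with a range from 18000 nM to 90000 nM.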

Compound 3, half-maximal cytotoxic concentration: 34700 nM
Compound 3: middle estimate off by 1.2-fold (0.06 log units), on the high side; measured number inside the range.
By their numbers in this assay, from the lowest: compounds 3, 2 and 1 (each within the scatter of the next).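

In this assay, the exchange of propyl for cyclopropyl on the amine nitrogen now has a direct reading (a 1.0-fold lower number from compound 2 to compound 3 (0.00 log units; within the scatter)), so the open chain and the small ring cannot be told apart at this position on this pair. Compound 3 also opens a second place to comparison, an aromatic carbon where cyano stands in place of 2-cyanoethenyl, and that exchange likewise stays inside the scatter (a 1.6-fold lower number from compound 1 to compound 3 (0.21 log units; within the scatter)), so neither of the two changes separates the compounds on this read-out. Nothing measured here speaks to the reason for these readings.

The compounds shown leave open whether other groups on the amine nitrogen, such as isopropyl, cyclopentyl or a hydroxyethyl chain, would also stay within the scatter of compound 2, or whether a larger group there would move the number beyond it. They also leave open whether a carboxylic acid or an amide in place of the cyano group on that aromatic carbon would separate a compound from compound 3 in this test.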